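The source may report more compounds than this note shows. Statements on the series, on what has been measured and on what is new or still open speak of the compounds shown alone.

Measured so far: compound 1 `C=CC(=O)N1C(=O)CC(c2ccc(OC)cc2)Sc2ccccc21`, 43300 nM; compound 2 `C=CC(=O)N1C(=O)CC(c2ccccc2C(F)(F)F)Sc2ccccc21`, 50300 nM.

Both numbers come from a functional assay on Raji cells (Homo sapiens) for cytotoxicity, read by CCK-8 assay, with a stated time of 24 h; a lower number here means a stronger inhibitor, a higher number a weaker inhibitor. In this assay compound 1 and compound 2 sit within the usual scatter of each other, so neither can be told apart from the other. Compound 3 `C=CC(=O)N1C(=O)CC(c2ccccc2)Sc2ccccc21` differs from compound 1 in one place: hydrogen in place of methoxy on an aromatic carbon. Within the data shown here, no measured pair shows a step of this kind, and both measured compounds give similarly high numbers, so in this assay a step no larger than the scatter is expected, in no particular direction. The expected step is a 1.2-fold higher number from compound 1 to compound 3 (0.06 log units; within the scatter). Compound 3 is thus expected to give about 50000 nM, with a range from 20000 nM to 120000 nM.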

Compound 3, half-maximal inhibitory concentration: 74100 nM
For compound 3 the middle estimate is 1.5-fold (0.17 log units) below the measured one; the measured number falls inside the stated range.
By their numbers in this assay, from the lowest: compounds 1, 2 and 3 (each within the scatter of the next).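

In this assay, replacing methoxy with hydrogen gives a 1.7-fold higher number from compound 1 to compound 3 (0.23 log units; within the scatter), and replacing trifluoromethyl with hydrogen gives a 1.5-fold higher number from compound 2 to compound 3 (0.17 log units; within the scatter). Compound 3, with its unsubstituted phenyl, therefore cannot be told apart from either substituted compound, so neither group is shown to matter here. No other measurement bears on this result.

As far as these compounds go, whether an amine or a carboxylic acid on this phenyl would give a step beyond the scatter remains open. So does the effect of any change to the shared core.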